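Two Fluorines in Place of One on the Phenyl

The compounds below may be only part of what the source reports. "The series", "measured", "known", "first", "only" and "open" are said of these compounds alone.

Measured compounds:
compound 1 `C[C@@H](NC(=O)c1ccc(C#Cc2ccccc2)cn1)C(C)(C)O` — 60.9%
compound 2 `C[C@@H](NC(=O)c1ccc(C#Cc2ccccc2F)cn1)C(C)(C)O` — 60%
compound 3 `C[C@@H](NC(=O)c1ccc(C#Cc2ccc(F)cc2)cn1)C(C)(C)O` — 66.2%

In a functional assay on HEK293 cells for positive allosteric modulation of metabotropic glutamate receptor 5 (Rattus norvegicus), read by fluorescence and calcium flux (on this read-out lower numbers stand for smaller maximal responses and higher numbers for larger maximal responses), compound 1 gives 60.9%, compound 2 gives 60% and compound 3 gives 66.2%. For the measured compounds named here, compound 3 holds the highest of the three numbers, yet its separation from the others is small: the step of a number 5.3 percentage points higher from compound 1 to compound 3 (within the scatter) and the step of a number 6.2 percentage points higher from compound 2 to compound 3 (within the scatter) both fall within the scatter, so no compound can be called more efficacious than another on these data.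

Compound 4 is `C[C@@H](NC(=O)c1ccc(C#Cc2cc(F)cc(F)c2)cn1)C(C)(C)O`. It differs from compound 3 in one place: 3,5-difluorophenyl in place of 4-fluorophenyl on a triple-bonded carbon. Going by the values given here, the steps that bear on this change all concern fluorine on the same phenyl. Adding one fluorine gave a number 0.9 percentage points lower from compound 1 to compound 2 (within the scatter) and a number 5.3 percentage points higher from compound 1 to compound 3 (within the scatter); moving it gave a number 6.2 percentage points higher from compound 2 to compound 3 (within the scatter). None of these left the scatter, and every measured compound sits in the same band. A second fluorine on that ring is therefore expected to leave the maximal response essentially where compound 3 has it, with no step beyond the scatter in either direction, that is a number 3.2 percentage points lower from compound 3 to compound 4 (within the scatter).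

Compound 4 is estimated to give 63% in this assay, with a range from 50% to 76%.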

Compound 4, largest response reached (reported as efficacy), in percent of the reference or control that the assay uses: 61.6%
Compound 4: middle estimate off by 1.4 percentage points, on the high side; the measured number falls inside the stated range.
By their numbers in this assay, from the lowest: compounds 2, 1, 4 and 3 (each within the scatter of the next).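

In this assay, 3,5-difluorophenyl in place of 4-fluorophenyl on the triple-bonded carbon gives a number 4.6 percentage points lower from compound 3 to compound 4 (within the scatter), while the same ring in place of 2-fluorophenyl gives a number 1.6 percentage points higher from compound 2 to compound 4 (within the scatter) and in place of phenyl gives a number 0.7 percentage points higher from compound 1 to compound 4 (within the scatter). The earlier compounds showed only that a single fluoro on this phenyl left the maximal response within the scatter, and compound 4 extends that finding to a ring carrying two fluoro groups, so that at this position all four rings shown stand level on this read-out. Nothing available bears on why the maximal response stays within the scatter across these rings.

The compounds shown leave open whether a group other than fluoro on this phenyl, such as methoxy, chloro, a nitrile or an amine, would produce a step beyond the scatter. They also leave open whether the maximal response would hold if the phenyl were kept and the chain on the amide nitrogen were replaced, for example by one ending in a carboxylic acid.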